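Chloro in Place of Trifluoromethoxy on a Shared Core

The source may hold more compounds than are shown below. What is called first, only, known or untested is meant among the compounds shown, and "the series" means these compounds.

Compound 1, `COc1cccc(N(C)/C(S)=C2/C(=O)c3cc(Cl)ccc3N(C)C2=O)c1`: 30%
Compound 2, `CN1C(=O)/C(=C(/S)N(C)c2ccc(OC(F)(F)F)cc2)C(=O)c2cc(Cl)ccc21`: 39%

Of the compounds shown here, two of one shared core have been tested in a functional assay on the whole organism for inhibition, with Mus musculus as the target, at a dose of 10 mg/kg by the oral route; on this read-out higher numbers stand for more inhibition at the one dose given (going by the name of the read-out) and lower numbers for less inhibition. Compound 1 gives 30% and compound 2 gives 39%. Compound 2 sits at the top of these two numbers only on paper: its gap to compound 1 lies within the usual scatter of repeated measurements, so the two results cannot be told apart.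

Compound 3, `CN1C(=O)/C(=C(/S)N(C)c2ccc(Cl)cc2)C(=O)c2cc(Cl)ccc21`, has not been measured. It differs from compound 2 in one place: chloro in place of trifluoromethoxy on an aromatic carbon. Both measured compounds carry a substituent at this place and land close together, so no step beyond the scatter is expected from compound 2 to compound 3 in this assay; the estimated step is a number 3 percentage points lower from compound 2 to compound 3 (within the scatter). Compound 3 is therefore expected to give about 36%, with a likely range from 18% to 54%.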

Compound 3, a percentage reported as inhibition, in the whole organism at one dose (the size of the read-out at that dose, not a potency): 47%
Estimate against measurement, compound 3: 11 percentage points below; low and high end bracket the measured number.
By their numbers in this assay, from the lowest: compounds 1, 2 and 3 (each within the scatter of the next, the first and the last beyond it).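

Chloro in place of trifluoromethoxy, on an aromatic carbon para to a large group, brings a number 8 percentage points higher from compound 2 to compound 3 (within the scatter) in this assay. So at this position, a group of one heavy atom cannot be told apart from one of five on this read-out. Among the compounds shown here, the wider change of 4-chlorophenyl in place of 3-methoxyphenyl on the amine nitrogen brings a number 17 percentage points higher from compound 1 to compound 3 (beyond the scatter) and is the only step here to clear the scatter, but it alters both the group and its place on the ring, and nothing available explains the result.

From the compounds shown here alone, it remains open whether a methyl, an amine or a carboxylic acid in place of chloro would hold this level of inhibition. Since each compound has a number at one dose only, these results also leave potency open.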